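A few compounds are considered here, and "the series" means these few. Any claim that something is new, unique, unknown or untested is made for them only; others in the source may bear on it.

Measured in an ADME assay on Karpas-1106P cells (Homo sapiens) for cytotoxicity; a lower number here means that less compound is needed, a higher number that more compound is needed for the effect:
- compound 1 `Cc1ccc(S(=O)(=O)N[C@@H](CC(=O)NC(C)(C)C)C(=O)NCCNC(=O)c2ccccc2Cl)cc1`: > 11100 nM
- compound 2 `Cc1ccc(S(=O)(=O)N[C@@H](CC(=O)NC(C)(C)C)C(=O)NCCNC(=O)c2cc(Cl)ccc2Cl)cc1`: > 11100 nM

Neither entry is a true number, and compound 2 has only a limit, > 11100 nM. Among the measured compounds shown here, the series so far rests entirely on (the limit of > 11100 nM in this assay, at which 2 of the 2 values shown sit).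

The next compound, compound 3 `Cc1ccc(S(=O)(=O)N[C@@H](CC(=O)NC(C)(C)C)C(=O)NCCNC(=O)NCc2ccccc2)cc1`, changes the end of the chain: benzylamino in place of 2,5-dichlorophenyl on a carbonyl carbon. Benzylamino takes the place of 2,5-dichlorophenyl on a carbonyl carbon. Both groups carry one six-membered aromatic ring of carbon only, and neither has a net charge.

For the measured compounds named here, the only measured step that bears on this is a step that the two limits leave unreadable from compound 1 to compound 2, where chloro replaces hydrogen on an aromatic carbon. It offers no size to carry over, and it concerns a different kind of change. No step beyond the scatter is therefore expected in this assay, and no direction can be predicted. The expected change is a step that the limit leaves unreadable from compound 2 to compound 3. Another report of only a limit is the likeliest outcome. For compound 3 the estimate is 15000 nM, with an expected range from 6000 nM to 40000 nM.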

Compound 3, half-maximal effective concentration: > 11100 nM
Compound 3 ended at the assay's limit (the forecaster's own chance of this, stated with the estimate: 85%); the middle value is on the limit's open side.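

Compound 3 gives > 11100 nM, which is a limit of the assay and not a true number. The steps to compound 3 from compound 1 and from compound 2 therefore cannot be read. The compounds shown leave open how much of any of them is needed for the effect in this assay, and the whole series still rests on one limit: the limit of > 11100 nM in this assay, at which 3 of the 3 values shown sit.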